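The source may report more compounds than this note shows. Statements on the series, on what has been measured and on what is new or still open speak of the compounds shown alone.

Compound 1 `COc1cc(OC)c(OC)cc1/C=C/C(=O)c1ccc(O)cc1O`: 2.37 ug/mL
Compound 2 `COc1cc(OC)c(C(=O)/C=C/c2cc(OC)c(OC)cc2OC)c(OC)c1`: 2.13 ug/mL
Compound 3 `COc1cc(OC)c(OC)cc1/C=C/C(=O)c1cccc([N+](=O)[O-])c1`: 2.21 ug/mL

These three values come from a functional assay on cells (Erythrocyte, Rattus norvegicus) for inhibition, read by hemolysis, with a stated time of 1 h (a higher number here means a weaker inhibitor, a lower number a stronger inhibitor), and they lie within the scatter of one another. Compound 1, at 2.37 ug/mL, therefore cannot be told apart from compound 3 at 2.21 ug/mL or from compound 2 at 2.13 ug/mL.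

The next compound to be tested is compound 4 `COc1cc(OC)c(OC)cc1/C=C/C(=O)c1ccc(O)cc1`, which has not yet been measured. It differs from compound 1 in one place, with hydrogen in place of hydroxy on an aromatic carbon. That carbon is ortho to a large group and meta to a hydroxy group, so 2,4-dihydroxyphenyl becomes 4-hydroxyphenyl.

Going by the values given here, no measured pair shows this change on its own, so the expectation rests on a looser observation. Compound 2, at 2.13 ug/mL, and compound 3, at 2.21 ug/mL, both carry other groups in place of the 2,4-dihydroxyphenyl of compound 1, yet their values remain within the scatter of it. On that basis, no step beyond the scatter is expected in this assay, and no direction is favoured. The expected change is a 1.0-fold lower number from compound 1 to compound 4 (0.01 log units; within the scatter). For compound 4 the estimated value is 2.3 ug/mL, with an expected range from 1.3 ug/mL to 4.2 ug/mL.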

Compound 4, half-maximal inhibitory concentration: 2.29 ug/mL
Compound 4: the middle estimate sits 1.0-fold (0.00 log units) above what was measured, within the range that was stated.
By their numbers in this assay, from the lowest: compounds 2, 3, 4 and 1 (each within the scatter of the next).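

In this assay the piece now has its first comparison confined to a single place, and it gives a 1.0-fold lower number from compound 1 to compound 4 (0.01 log units; within the scatter) with hydrogen in place of hydroxy on an aromatic carbon. Compound 2 and compound 3 differ from compound 1 in more than one place and so could not speak for this carbon alone, whereas here 2,4-dihydroxyphenyl and 4-hydroxyphenyl cannot be told apart, which shows that the hydroxy on this carbon, ortho to a large group and meta to a hydroxy group, can give way to hydrogen without a step that rises above the scatter. Nothing available explains this result, and no supporting measurement bears on it.

The compounds shown leave open whether a different group on this same carbon, such as an amine or a carboxylic acid, would also stay within the scatter of compound 1. Going by these compounds alone, they also leave open what happens when the hydroxy that remains in the 4-hydroxyphenyl of compound 4 is itself replaced by hydrogen, since no pair isolates that change.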